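Replacing the hydroxyphenyl ring with a pyridyl ring

The source may hold more compounds than are shown below. What is called first, only, known or untested is meant among the compounds shown, and "the series" means these compounds.

Measured so far:
compound 1, `Cn1cc(/C=C2/C(=O)Nc3ccccc32)c2cc(Nc3nccc(-c4ccc(O)cc4)n3)ccc21`: 13200 nM
compound 2, `Cn1cc(/C=C2/C(=O)Nc3ccccc32)c2cc(Nc3nccc(-c4ccc(F)cc4)n3)ccc21`: 16400 nM
compound 3, `Cn1cc(/C=C2/C(=O)Nc3ccccc32)c2cc(Nc3nccc(-c4ccc(C(F)(F)F)cc4)n3)ccc21`: 26000 nM

All three were tested in a functional assay on U-87MG ATCC cells (Homo sapiens) for cytotoxicity, read by MTT assay, with a stated time of 48 h; a lower number here means a stronger inhibitor, a higher number a weaker inhibitor. On the numbers alone compound 1 stands lowest of the three, but the steps of a 1.2-fold higher number from compound 1 to compound 2 (0.09 log units; within the scatter) and a 2.0-fold higher number from compound 1 to compound 3 (0.29 log units; within the scatter) both lie within the scatter, as does a 1.6-fold higher number from compound 2 to compound 3 (0.20 log units; within the scatter), so none of the three can be told apart with confidence.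

Compound 4, `Cn1cc(/C=C2/C(=O)Nc3ccccc32)c2cc(Nc3nccc(-c4cccnc4)n3)ccc21`, has not yet been tested. It differs from compound 1 in one place: pyridin-3-yl in place of 4-hydroxyphenyl on an aromatic carbon. Going by the values given here, no measured step covers this exact exchange. The three measured steps only changed the substituent on the ring that is now being replaced, and all of them stayed within the scatter, which gives little reason to expect a large shift when the ring itself is swapped. Compound 4 is therefore expected to give about 15000 nM in this assay, within a range of 6000 nM to 40000 nM. This corresponds to an expected step of a 1.1-fold higher number from compound 1 to compound 4 (0.06 log units; within the scatter), which would not go beyond the scatter.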

Compound 4, half-maximal inhibitory concentration: 14800 nM
For compound 4 the middle estimate is 1.0-fold (0.01 log units) above the measured one; the range from low to high includes it.
By their numbers in this assay, from the lowest: compounds 1, 4, 2 and 3 (each within the scatter of the next).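

In this assay, going by these compounds alone, the earlier compounds changed only the substituent on a phenyl ring, whereas compound 4 replaces the whole 4-hydroxyphenyl group with pyridin-3-yl, a ring with one hetero atom and without the hydrogen-bond donor of 4-hydroxyphenyl. All three new steps (a 1.1-fold higher number from compound 1 to compound 4 (0.05 log units; within the scatter); a 1.1-fold lower number from compound 2 to compound 4 (0.04 log units; within the scatter); a 1.8-fold lower number from compound 3 to compound 4 (0.24 log units; within the scatter)) lie within the scatter, so on this aromatic carbon next to the ring nitrogen, the ring exchange and the loss of that donor produce no readable difference in this set. No measurement shown explains this result.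

From the compounds shown here alone, it remains open whether pyridin-4-yl, a saturated ring such as piperidine, or a phenyl ring carrying an amine or a carboxylic acid would move the number beyond the scatter. Every compound shown also keeps the shared core, so the effect of changes elsewhere in the molecule remains open too.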